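A ring hydroxy on compound 1: what to expect

The source may report more compounds than this note shows. Statements on the series, on what has been measured and on what is new or still open speak of the compounds shown alone.

compound 1 `CCCCCCCC/N=C/N1CCC(C(c2ccccc2)c2ccccc2)CC1` gives 3.9 mg/kg
compound 2 `CC(O)CCCCCC/N=C/N1CCC(C(c2ccccc2)c2ccccc2)CC1` gives 8.9 mg/kg

In a functional assay on the whole organism (stomach) with Rattus norvegicus as the target (a lower number here means that less compound is needed, a higher number that more compound is needed for the effect), compound 1 holds the lower of the two numbers, so less of it is needed for the effect. For the measured compounds named here, its only measured neighbour is compound 2. The next molecule, compound 3 `CCCCCCCC/N=C/N1CCC(C(c2ccccc2)c2ccc(O)cc2)CC1`, keeps the core of compound 1 and changes a single place: hydroxy in place of hydrogen on an aromatic carbon on an aromatic carbon of a six-membered aromatic ring of carbon only, para to a large group, which reads as phenyl to 4-hydroxyphenyl.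

Going by the values given here, only one measured step bears on this, again hydroxy in place of hydrogen but on a saturated chain carbon: a 2.3-fold higher number from compound 1 to compound 2 (0.36 log units; beyond the scatter) which counts as modest. Among the compounds with values here, no measured compound carries hydroxy on an aromatic carbon, so this is a loose guide. A modest step toward a higher number in this assay is the expectation, although a step within the scatter remains possible. The estimate amounts to a 2.1-fold higher number from compound 1 to compound 3 (0.31 log units; beyond the scatter) as the expected step. The dose for compound 3 is estimated at 8 mg/kg with 2.5 mg/kg to 25 mg/kg as its expected range.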

Compound 3, dose for half-maximal effect: > 40 mg/kg
Compound 3: no number, only a limit; the forecaster's own chance of this, stated with the estimate: 5%; middle value at least 5.0-fold (0.69 log units) away from the limit.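

The same exchange of hydrogen for hydroxy can differ greatly in size with its place: on an aromatic carbon of the ring, it gives an at least 10-fold higher number from compound 1 to compound 3 (1.01 log units; beyond the scatter) in this assay, whereas on a saturated chain carbon, it gives only a 2.3-fold higher number from compound 1 to compound 2 (0.36 log units; beyond the scatter). This para position on the ring is therefore far more sensitive to the change than the chain position, though each place is represented by one example only, so no general rule follows. The reading for compound 3 is a limit of the assay and not a number, and it is the only such reading among the compounds shown: the limit of > 40 mg/kg in this assay, at which 1 of the 3 values shown sits.

As far as these compounds go, what remains open is whether hydroxy itself matters here or whether any new group at this place would bring a step of similar size, which a methoxy group or a fluorine on the same aromatic carbon could help to settle. From the compounds shown here alone, it is also open whether an amine at this place, or hydroxy elsewhere on the ring, would give a smaller step than the one seen with 4-hydroxyphenyl.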